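Sulfonamide piperidines: cytotoxicity notes toward compound 3

This account rests on a few compounds, and the source may have more. Where it says the series, first, only, none or still open, it means among the compounds named here.

Working notes on the series. Compound 2 `Cc1cc(C)c(S(=O)(=O)N2CCC(C(=O)N3CCC(C)CC3)CC2)c(C)c1` was run in an ADME assay on HCT-116 cells (Homo sapiens) for cytotoxicity, read by CellTiter-Glo, with a stated time of 72 h; on this read-out higher numbers stand for weaker inhibition and lower numbers for stronger inhibition. In this assay compound 2 gives > 5000 nM, which is a limit of the assay and not a number. Compound 1 `CC1CCN(C2CCN(S(=O)(=O)c3ccc(F)cc3F)CC2)CC1` is the other measured member. In this assay compound 1 gives > 5000 nM, again a limit rather than a number. Both shown values sit at the limit of > 5000 nM in this assay, at which 2 of the 2 values shown sit, so compound 2 stands level with everything measured so far and no ordering among the measured compounds can be drawn. Compound 3 `Cc1ccc(C2CCN(S(=O)(=O)c3c(C)cc(C)cc3C)CC2)cc1` is not yet measured. It differs from compound 2 by 4-methylphenyl in place of (4-methylpiperidin-1-yl)carbonyl on a saturated ring carbon. Among the measured compounds shown here, no step between measured compounds is available for this change. With both measured neighbours at the limit, compound 3 is expected to stay near it, and the estimated step is a step that the limit leaves unreadable from compound 2 to compound 3, none beyond the scatter, with no direction claimed. For compound 3 the estimate in this assay is 8000 nM, within 2000 nM to 30000 nM.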

Compound 3, half-maximal inhibitory concentration: > 5000 nM
Compound 3 was reported as a limit; the forecaster's own chance of this, stated with the estimate: 80%; the middle value does not contradict the limit.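

In this assay compound 2 and compound 3 are both reported as limits and not as numbers, so no step can be read between them. The compounds shown leave open where their actual values lie and whether any change among them alters cytotoxicity.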